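The compounds below may be only part of what the source reports. "The series", "measured", "known", "first", "only" and "open" are said of these compounds alone.

Of the compounds shown here, two built on one shared core have been measured. In a functional assay on MV4-11 cells (Homo sapiens) for antiproliferative activity, with a stated time of 6 days, tested at 1.56 uM (a higher number here means a stronger effect of the compound at the concentration tested, a lower number a weaker effect), compound 1 `CNC(=O)N1CCCc2ccc(NC(=O)c3ccc(-c4ccccc4)cc3)cc21` gives 19.7%, the higher of the two numbers, while compound 2 `CNC(=O)N1CCCc2ccc(NC(=O)c3cccc(-c4cnn(S(C)(=O)=O)c4)c3)cc21` gives 1.6%, a gap beyond the usual scatter. Compound 3 `CNC(=O)N1CCCc2ccc(NC(=O)c3ccc(-c4cnn(S(C)(=O)=O)c4)cc3)cc21` is compound 1 with 1-(methylsulfonyl)-1H-pyrazol-4-yl in place of phenyl on an aromatic carbon. Within the data shown here, no measured pair shows exactly this change, so the expectation leans on compound 2 and its low 1.6%. A downward step from compound 1 to compound 3 is expected in this assay, roughly a number 12.7 percentage points lower from compound 1 to compound 3 (beyond the scatter). For compound 3 an inhibition of about 7% is estimated, between 0% and 20%.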

Compound 3, a percentage reported as inhibition, at one concentration (the size of the read-out at that concentration, not a potency): 4.5%
Compound 3: middle estimate off by 2.5 percentage points, on the high side; low and high end bracket the measured number.
By their numbers in this assay, from the lowest: compounds 2 and 3 (each within the scatter of the next); then compound 1.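

Replacing phenyl with 1-(methylsulfonyl)-1H-pyrazol-4-yl on the aromatic carbon para to a large group gives a number 15.2 percentage points lower from compound 1 to compound 3 (beyond the scatter) in this assay. Among these compounds, this is the first pair to isolate that swap, so the loss can be assigned to the change of group, with the rest of the molecule held the same. No measurement shown here explains the drop.

Still open, as far as these compounds go, is whether a plain pyrazol-4-yl, without the methylsulfonyl, would retain the effect seen with phenyl. A simple amine or a carboxylic acid at this position also remains untested in the compounds shown.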